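Pyrrolidin-1-yl for piperidin-1-yl: cytotoxicity step in the series

This account rests on a few compounds, and the source may have more. Where it says the series, first, only, none or still open, it means among the compounds named here.

In an ADME assay on Huh7.5.1 cells (Homo sapiens) for cytotoxicity, read by WST assay, with a stated time of 48 h (on this read-out lower numbers stand for higher toxicity in this test and higher numbers for lower toxicity in this test), compound 3 (`Cc1c(-c2ccc(Oc3ccc(N4CCCCC4)cc3)c(F)c2)[nH]c2cccc(F)c2c1=O`) gives > 10000 nM as its reading, a limit of the assay and not a number. Compound 2 (`Cc1c(-c2ccc(Oc3ccc(SC(F)(F)F)cc3)c(F)c2)[nH]c2cccc(F)c2c1=O`) gives > 10000 nM as its reading, also a limit. Compound 1 (`Cc1c(-c2ccc(Cc3ccc(C(C)(C)C)cc3)cc2)[nH]c2cccc(F)c2c1=O`) gives > 5000 nM as its reading, again a limit. No number has yet been read in this assay for any of the three, so compound 3 has no ranked place among them.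

Compound 4 (`Cc1c(-c2ccc(Oc3ccc(N4CCCC4)cc3)c(F)c2)[nH]c2cccc(F)c2c1=O`) carries pyrrolidin-1-yl in place of piperidin-1-yl on an aromatic carbon, para to a large group (pyrrolidin-1-yl in place of piperidin-1-yl on an aromatic carbon). Within the data shown here, the one measured step at this place is a step that the two limits leave unreadable from compound 2 to compound 3 and it offers no size to carry over. It does show two different groups there, both ending in a limit. No step beyond the scatter is therefore expected in this assay, and no direction is favoured. The expected change is a number no higher from compound 3 to compound 4 (the limit leaves the size open) and it stays small. For compound 4 the estimate is 10000 nM with an expected range from 5000 nM to 20000 nM and a report as a limit is the likeliest outcome.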

Compound 4, half-maximal cytotoxic concentration: > 10000 nM
Compound 4 gave a limit, no number; the forecaster's own chance of this, stated with the estimate: 85%; the middle value sits exactly at the limit.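

Compound 4 gives > 10000 nM in this assay, a limit and not a number. Among these compounds, no step among compound 2, compound 3 and compound 4 can be read. The compounds shown leave open where the half-maximal cytotoxic concentration of each actually lies, and whether exchanging these groups changes it.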